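From pyridin-4-yl to 2-chlorophenyl at the limit of tolerance

The compounds below may be only part of what the source reports. "The series", "measured", "known", "first", "only" and "open" are said of these compounds alone.

In a toxicity assay on THP-1 cells (Homo sapiens) for inhibition (a lower number here means that less compound is tolerated, a higher number that more compound is tolerated), compound 3 (`COc1ccc(-c2cnc(NC(=O)c3ccncc3)n2C)cc1`) reads > 100000 nM and that is a limit, not a number. Compound 2 (`COc1ccc(-c2cnc(NC(=O)c3cccc(C)c3)n2C)cc1`) reads > 100000 nM and that too is a limit. Compound 1 (`COc1ccc(-c2cnc(NC(=O)c3ccc(F)cc3)n2C)cc1`) reads >= 50000 nM and this is also a limit. Compound 3 therefore stands at the limit of > 100000 nM in this assay, at which 2 of the 3 values shown sit, while compound 1 stands at the limit of >= 50000 nM in this assay, at which 1 of the 3 values shown sits, in the same series.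

The change to compound 4 (`COc1ccc(-c2cnc(NC(=O)c3ccccc3Cl)n2C)cc1`) is 2-chlorophenyl in place of pyridin-4-yl on a carbonyl carbon and it puts 2-chlorophenyl in place of pyridin-4-yl on a carbonyl carbon. Three measured steps alter that same place: a step that the two limits leave unreadable from compound 1 to compound 2 and a step that the two limits leave unreadable from compound 1 to compound 3 and also a step that the two limits leave unreadable from compound 2 to compound 3 among them. None of them has a size that can be read. No step beyond the scatter is therefore expected in this assay and no direction can be drawn from them.

The estimated change is an at least 1.2-fold lower number from compound 3 to compound 4 (0.09 log units; that floor lies within the scatter) and it is read against a limit, not a number. Compound 4 is expected at about 80000 nM with an estimated range from 30000 nM to 200000 nM and it may well return only a limit.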

Compound 4, half-maximal cytotoxic concentration: > 50000 nM
Compound 4: no number, only a limit; the forecaster's own chance of this, stated with the estimate: 75%; the middle value does not contradict the limit.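

In this assay, going by these compounds alone, compound 4 gives > 50000 nM, which is a limit, and compound 1, compound 2 and compound 3 also return only limits, so no step to compound 4 can be read. The compounds shown leave open whether changing the group on the carbonyl carbon alters tolerance in this assay at all.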